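Azetidinone series: aryl swap at the saturated ring carbon

The source may report more compounds than this note shows. Statements on the series, on what has been measured and on what is new or still open speak of the compounds shown alone.

Measured so far in a functional assay on IMR-32 cells (Homo sapiens) for cytotoxicity; on this read-out lower numbers stand for stronger inhibition and higher numbers for weaker inhibition:
compound 1 `COc1ccc(C2C(OC(C)=O)C(=O)N2c2cc(OC)c(OC)c(OC)c2)cc1N`: 73.1 nM
compound 2 `COc1ccc(C2C(OC)C(=O)N2c2cc(OC)c(OC)c(OC)c2)cc1N`: > 1000 nM

Within the data shown here, compound 1 holds the only numerical value in this assay; the other entry is a limit. Compound 2 gives > 1000 nM in this assay, which is a limit of the assay rather than a number. Among the measured compounds shown here, the one measured step, methyl in place of acetyl on an oxygen on a saturated carbon, gives an at least 13-fold higher number from compound 1 to compound 2 (1.13 log units; beyond the scatter), with compound 2 sitting at the limit of > 1000 nM in this assay, at which 1 of the 2 values shown sits.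

Compound 3 `COc1cc(N2C(=O)C(OC(C)=O)C2c2ccc([N+](=O)[O-])o2)cc(OC)c1OC` keeps the acetoxy group and the core of compound 1 and changes only the aryl group on the saturated ring carbon: 5-nitrofuran-2-yl in place of 3-amino-4-methoxyphenyl on a saturated ring carbon. For the measured compounds named here, no measured step touches this position, so the step from compound 1 to compound 2 bears on compound 3 only in that the acetyl group, whose loss weakened inhibition, is retained. For compound 3 a moderate step toward a higher number is expected, a 3.4-fold higher number from compound 1 to compound 3 (0.53 log units; beyond the scatter), with a wide range. Compound 3 is estimated at 250 nM, between 60 nM and 1000 nM.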

Compound 3, half-maximal inhibitory concentration: 811 nM
Beside the measured number, compound 3's estimate is 3.2-fold (0.51 log units) below it; the measured number falls inside the stated range.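

In this assay the aryl group on the saturated ring carbon proves to count in its own right: with the acetoxy group and the core of compound 1 held fixed, 5-nitrofuran-2-yl in place of 3-amino-4-methoxyphenyl gives an 11-fold higher number from compound 1 to compound 3 (1.05 log units; beyond the scatter) and so weaker inhibition. The acetoxy group alone is therefore not enough to hold the value of compound 1, and the two places changed so far, the oxygen substituent and this aryl group, each give a large step when changed on their own. Unlike the change at the oxygen, this swap still gives a number and not a limit, with compound 3 at 811 nM in this assay and so still open to comparison with further changes at this position.

Nothing shown here gives a reason for this step. The swap replaces the whole aryl group in one move, so the shares of the ring, the amine and the methoxy group stay unresolved, and a plain phenyl, a 4-methoxyphenyl without the amine, or a furan-2-yl without the nitro group at this place would begin to separate them.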